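A few compounds are considered here, and "the series" means these few. Any claim that something is new, unique, unknown or untested is made for them only; others in the source may bear on it.

Of the compounds shown here, three sharing one core have been read in a physicochemical assay for solubility, using the shake flask method, in simulated intestinal fluid, measured as kinetic solubility, with a stated time of 20 h, at pH 6.5; on this read-out lower numbers stand for lower solubility and higher numbers for higher solubility. Compound 1 `FC(F)(F)c1ccc(Nc2cc3[nH]c(-c4cccc(C(F)(F)F)c4)nc3cn2)nc1`, which carries 3-(trifluoromethyl)phenyl, returned only a limit, >= 50000 nM. Compound 2 `FC(F)(F)c1ccc(Nc2cc3[nH]c(C4CC4)nc3cn2)nc1` gives 123000 nM, and compound 3 `FC1(F)CC(c2nc3cnc(Nc4ccc(C(F)(F)F)cn4)cc3[nH]2)C1` gives 161000 nM. These two numbers stand level, so compound 3 sits alongside compound 2 and has no clear lead. Compound 1 offers no size to work with, as shown by a step that the limit leaves unreadable from compound 1 to compound 3 and by a step that the limit leaves unreadable from compound 1 to compound 2.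

Compound 4 `FC1(F)CCC(c2nc3cnc(Nc4ccc(C(F)(F)F)cn4)cc3[nH]2)CC1` has not yet been measured. It has 4,4-difluorocyclohexyl in place of 3,3-difluorocyclobutyl on an aromatic carbon. Among the measured compounds shown here, the only readable precedent is also an exchange of one non-aromatic carbon ring for another at this place, and it is small: a 1.3-fold higher number from compound 2 to compound 3 (0.12 log units; within the scatter), within the scatter. On that single step, no change beyond the scatter is expected in this assay, so no direction can be called with confidence. The expected step is a 1.3-fold lower number from compound 3 to compound 4 (0.13 log units; within the scatter). For compound 4 the estimated value is 120000 nM, with an expected range from 50000 nM to 220000 nM.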

Compound 4, solubility: 93000 nM
Compound 4: middle estimate off by 1.3-fold (0.11 log units), on the high side, within the range that was stated.
By their numbers in this assay, from the lowest: compounds 4, 2 and 3 (each within the scatter of the next).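

At this place, on an aromatic carbon between two ring nitrogen atoms, 4,4-difluorocyclohexyl in place of 3,3-difluorocyclobutyl in this assay gives a 1.7-fold lower number from compound 3 to compound 4 (0.24 log units; within the scatter), and the same group in place of cyclopropyl gives a 1.3-fold lower number from compound 2 to compound 4 (0.12 log units; within the scatter). The earlier compounds shown here offered a single readable exchange of one non-aromatic carbon ring for another, whereas these three compounds now give three such exchanges, and all of them lie within the scatter, even with the six-membered ring entering. Steps from compound 1, including the one to compound 4, cannot be read because its value is a limit: the limit of >= 50000 nM in this assay, at which 1 of the 4 values shown sits.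

As far as these compounds go, it remains open whether an amine or a carboxylic acid at this place would shift the number beyond the scatter. How 3-(trifluoromethyl)phenyl truly compares with these non-aromatic rings also stays unresolved.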